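Cyclopropyl to cyclobutyl on two related sulfonyl cores

This account rests on a few compounds, and the source may have more. Where it says the series, first, only, none or still open, it means among the compounds named here.

Compound 1 `O=S1(=O)N=C(NC2CC2)Nc2cc(Cl)ccc21` is tested in a functional assay on aorta (Rattus norvegicus) for inhibition (on this read-out lower numbers stand for an effect already at smaller amounts and higher numbers for an effect only at larger amounts of compound), and gives 156000 nM. Compound 2 `O=S1(=O)N=C(NC2CCC2)Nc2cc(Cl)ccc21` differs from it by cyclobutyl in place of cyclopropyl on an amine nitrogen. In this assay compound 2 yields only a limit, > 300000 nM, not a number. The resulting step is an at least 1.9-fold higher number from compound 1 to compound 2 (0.28 log units; that floor lies within the scatter), and it rests on (the limit of > 300000 nM in this assay, at which 1 of the 3 values shown sits). Compound 3 `O=S1(=O)N=C(NC2CC2)Nc2ccc(Cl)cc21` shares the same atoms with compound 1 but joined differently; how the two cores differ is not broken down here. In this assay compound 3 gives 191000 nM, a value within the scatter of that of compound 1. Compound 4 `O=S1(=O)N=C(NC2CCC2)Nc2ccc(Cl)cc21` is not yet measured and differs from compound 3 by cyclobutyl in place of cyclopropyl on an amine nitrogen. This is the same change as that from compound 1 to compound 2, made on the other core. The step from compound 3 to compound 4 is expected to be a 2.1-fold higher number from compound 3 to compound 4 (0.32 log units; beyond the scatter), set beside the measured at least 1.9-fold higher number from compound 1 to compound 2 (0.28 log units; that floor lies within the scatter), with the assay limit again likely to be reached. For compound 4 the estimate in this assay is 400000 nM, with a range from 200000 nM to 900000 nM.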

Compound 4, half-maximal effective concentration: 34900 nM
Beside the measured number, compound 4's estimate is 11-fold (1.06 log units) above it, outside the stated range (below it).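

The change from cyclopropyl to cyclobutyl on an amine nitrogen gives a 5.5-fold lower number from compound 3 to compound 4 (0.74 log units; beyond the scatter) in this assay, and the same change points the other way on the other core, so in this series its result does not carry from one core to the other: the same change on two cores in this assay, an at least 1.9-fold higher number (0.28 log units; that floor lies within the scatter) from compound 1 to compound 2 and a 5.5-fold lower number (0.74 log units; beyond the scatter) from compound 3 to compound 4, at least 10-fold (1.02 log units) apart, beyond the scatter of two such steps

From the compounds shown here alone, compound 2 gives only > 300000 nM in this assay, which is a limit of the assay and not a number, so the size of its step remains unknown. These two pairs do not show why the cores part ways, and they cannot predict what the change would do on any further core.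

With only cyclopropyl and cyclobutyl shown on the amine nitrogen, it remains open whether a cyclopentyl ring or an open chain such as isopropyl would follow compound 4 or compound 2. Going by these compounds, it is also open whether the split between the cores would persist if a fluorine or a methoxy group stood in place of the chlorine.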